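The source may hold more compounds than are shown below. What is called first, only, known or untested is meant among the compounds shown, and "the series" means these compounds.

Within the data shown here, compound 1, `COc1ncc(-c2ccc3ncnc(Nc4ccc(OCCO)cc4)c3c2)cc1NS(=O)(=O)c1ccc(F)cc1F`, is one of three compounds measured in a functional assay on MCF7 cells (Homo sapiens) for antiproliferative activity, read by sulforhodamine B assay, with a stated time of 72 h (a higher number here means a weaker inhibitor, a lower number a stronger inhibitor), where compound 1 gives 1650 nM. Compound 2, `COC(=O)CCn1cc(Nc2ncnc3ccc(-c4cnc(OC)c(NS(C)(=O)=O)c4)cc23)cn1`, gives 490 nM, and compound 3, `COc1ncc(-c2ccc3ncnc(Nc4ccc(OCCO)nc4)c3c2)cc1NS(C)(=O)=O`, gives 3080 nM. Compound 1 stands second highest of the three: close to compound 3, within the scatter, but a beyond-the-scatter gap from compound 2. The new compound 4, `COc1ncc(-c2ccc3ncnc(Nc4ccc(OCCCO)nc4)c3c2)cc1NS(=O)(=O)c1ccc(F)cc1F`, differs from compound 1 by 6-(3-hydroxypropoxy)pyridin-3-yl in place of 4-(2-hydroxyethoxy)phenyl on a nitrogen on an aromatic ring. Among the measured compounds shown here, no measured step pairs a 4-(2-hydroxyethoxy)phenyl with a pyridin-3-yl on this nitrogen; the only step there, a 6.3-fold higher number from compound 2 to compound 3 (0.80 log units; beyond the scatter), exchanges a pyrazolyl instead, so it bears on the change only loosely. Compound 1 and compound 3 differ in two places at once, yet their values lie within the scatter. Compound 4 is therefore expected at 2200 nM, between 900 nM and 5500 nM, a step of a 1.3-fold higher number from compound 1 to compound 4 (0.12 log units; within the scatter) that is expected to stay near the scatter.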

Compound 4, half-maximal inhibitory concentration: 6120 nM
Compound 4: the middle estimate sits 2.8-fold (0.44 log units) below what was measured; the measured number lies above the stated range.
By their numbers in this assay, from the lowest: compound 2; then compounds 1, 3 and 4 (each within the scatter of the next, the first and the last beyond it).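

In this assay, placing 6-(3-hydroxypropoxy)pyridin-3-yl on this nitrogen in place of 4-(2-hydroxyethoxy)phenyl gives a 3.7-fold higher number from compound 1 to compound 4 (0.57 log units; beyond the scatter), with the rest of the structure unchanged. This shows that the position can distinguish two six-membered aromatic rings that each carry a hydroxy-ended chain, whereas the earlier step here exchanged a pyrazolyl group. Nothing available explains this step.

Because the ring and the chain length change together, the compounds shown leave open which change accounts for the step. They also leave open how an amine or a carboxylic acid at the chain end would fare.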